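Chloro in place of tert-butyl: an estimate for compound 4

This account rests on a few compounds, and the source may have more. Where it says the series, first, only, none or still open, it means among the compounds named here.

Compound 1 `Cc1ccc(O)c(/C=N/NC(=O)c2ccc(C(C)(C)C)cc2)c1` gives 16300 nM in a functional assay on MRC5 cells (Homo sapiens) for cytotoxicity, read by colorimetric assay and MTT assay (on this read-out higher numbers stand for lower toxicity in this test and lower numbers for higher toxicity in this test), the highest of the two numbers shown. Compound 3 `CC(C)(C)c1ccc(O)c(/C=N/NC(=O)c2cccs2)c1` gives 12000 nM in this assay, which sits within the usual scatter of the value for compound 1. Compound 2 `CC(C)(C)c1ccc(C(=O)N/N=C/c2cc(Br)ccc2O)cc1` reaches the limit > 100000 nM in this assay, a limit and not a number (the limit of > 100000 nM in this assay, at which 1 of the 3 values shown sits).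

Compound 4 `Cc1ccc(O)c(/C=N/NC(=O)c2ccc(Cl)cc2)c1` differs from compound 1 by chloro in place of tert-butyl on an aromatic carbon. For the measured compounds named here, the only measured step, an at least 6.1-fold higher number from compound 1 to compound 2 (0.78 log units; beyond the scatter), concerns a different change at a different site and so does not bear directly on this one. Going by the values given here, with no comparable step, no movement beyond the scatter is expected in this assay. Compound 4 is therefore estimated at 16000 nM, from 6000 nM to 50000 nM. The expected step is a 1.0-fold lower number from compound 1 to compound 4 (0.01 log units; within the scatter).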

Compound 4, half-maximal cytotoxic concentration: > 100000 nM
Compound 4: no number, only a limit (the forecaster's own chance of this, stated with the estimate: 15%); middle value at least 6.2-fold (0.79 log units) away from the limit.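

Chloro in place of tert-butyl, on an aromatic carbon para to a large group, gives an at least 6.1-fold higher number from compound 1 to compound 4 (0.78 log units; beyond the scatter) in this assay. For the compounds shown here, this is the first step at this position, and it shows that the read-out responds to the tert-butyl site as well as to the site of the earlier methyl-to-bromo change. Compound 4 gives only a limit, so the true size of this step stays unresolved: the limit of > 100000 nM in this assay, at which 2 of the 4 values shown sit.

Going by these compounds, whether the read-out depends on the loss of tert-butyl or on the arrival of chloro stays open. An amine or a carboxylic acid at this carbon would help separate the two.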